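Notes on the step from compound 3 to compound 4

The source may hold more compounds than are shown below. What is called first, only, known or untested is meant among the compounds shown, and "the series" means these compounds.

Measured so far:
compound 1, `CCC(C(=O)N1CCN(c2ccc(C(F)(F)F)cc2)CC1)N1C(=O)CCC1=O`, 0%
compound 2, `CCC(C(=O)N1CCN(c2cccc(C(F)(F)F)c2)CC1)N1C(=O)CCC1=O`, 50%
compound 3, `CCC(C(=O)N1CCN(c2ccc(Cl)cc2)CC1)N1C(=O)CCC1=O`, 25%

In a functional assay on the whole organism (strain Swiss) with Mus musculus as the target, in the maximal electroshock model, with a stated time of 2 h, at a dose of 300 mg/kg by the intraperitoneal route (on this read-out lower numbers stand for a weaker effect and higher numbers for a stronger effect at the one dose given), compound 3 gives 25%, the second highest of the three numbers. Among the compounds with values here, the one measured single-point step, a number 25 percentage points higher from compound 1 to compound 3 (beyond the scatter), is the change chloro in place of trifluoromethyl on an aromatic carbon. Within the data shown here, compound 2 gives 50%, which is higher than the number of compound 3, but no single-point step links those two.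

Compound 4 is `CCC(C(=O)N1CCN(c2ccccc2)CC1)N1C(=O)CCC1=O`. It differs from compound 3 in one place: hydrogen in place of chloro on an aromatic carbon. Among the measured compounds shown here, no measured step removes a substituent from that aromatic carbon altogether; the step from compound 1 to compound 3 only exchanges one substituent for another at the same place and bears on this change indirectly. It shows that the identity of the group on that carbon moves the read-out by a modest amount, so the removal could move it either way by a similar size, with no clear direction. The working expectation is no change at the digits printed from compound 3 to compound 4 (within the scatter), a step not beyond the scatter. Compound 4 is therefore estimated at 25%, within 0% to 55%.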

Compound 4, a percentage reported as activity, at one dose (the size of the read-out at that dose, not a potency): 25%
The estimate for compound 4 equals the measured number at the digits printed; the measured number falls inside the stated range.
By their numbers in this assay, from the lowest: compound 1; then compounds 3 and 4 (each within the scatter of the next); then compound 2.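

In this assay, within the data shown here, this is the first reading of the position with no substituent: no change at the digits printed from compound 3 to compound 4 (within the scatter), so 4-chlorophenyl to phenyl leaves the number within the scatter. Alongside this, a number 25 percentage points higher from compound 1 to compound 4 (beyond the scatter) ties the low number of compound 1 to trifluoromethyl at this place specifically, as chloro and hydrogen do not separate here. The step of a number 25 percentage points lower from compound 2 to compound 4 (beyond the scatter) runs the other way, so trifluoromethyl goes with a lower number than hydrogen in compound 1 and a higher one in compound 2, the two differing in where the group sits on the ring.

No evidence at hand gives a cause for these steps. From the compounds shown here alone, whether a methoxy group, an amine or a carboxylic acid at this place would hold or shift the number of compound 4 stays open.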